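The compounds below may be only part of what the source reports. "The series", "measured", "known", "first", "only" and "open" are said of these compounds alone.

Measured so far in a functional assay on a cell-free system (plasma, Oryctolagus cuniculus) for inhibition, with stated times of 5 min, 1 min and 6 min; a higher number here means a weaker inhibitor, a lower number a stronger inhibitor:
- compound 1 `CCOC(=O)c1c(C)nc(-c2ccc(OCC(C)C)c(C#N)c2)n1O`: 16800 nM
- compound 2 `CCOC(=O)c1c(C)nc(-c2ccccc2)n1OC`: > 30000 nM
- compound 3 `CCOC(=O)c1[nH]c(-c2cccc(C#N)c2)nc1C`: > 30000 nM

Compound 3 has no number: its > 30000 nM is a limit of the assay. Only compound 1 gives a numerical reading, 16800 nM.

The next compound is compound 4 `C=CCOn1c(-c2cccc(C#N)c2)nc(C)c1C(=O)OCC`. Relative to compound 3, the change is allyloxy in place of hydrogen on an aromatic nitrogen.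

Going by the values given here, no measured pair isolates this change, so the expectation rests on indirect evidence. Compound 2 also carries an oxygen-linked group on an aromatic nitrogen, and its > 30000 nM is likewise a limit of the assay. A large gain is therefore not expected. The expected step is an at least 1.2-fold lower number from compound 3 to compound 4 (0.07 log units; that floor lies within the scatter) in this assay, toward a stronger inhibitor if it moves at all, and not beyond the scatter. Another limit reading is also quite likely. For compound 4 the estimated value is 25000 nM, with an expected range of 9000 nM to 60000 nM.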

Compound 4, half-maximal inhibitory concentration: 5860 nM
Compound 4: middle estimate off by 4.3-fold (0.63 log units), on the high side; the whole stated range lies above it.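

In this assay, going by these compounds alone, allyloxy in place of hydrogen on the aromatic nitrogen gives the first step that can be read: an at least 5.1-fold lower number from compound 3 to compound 4 (0.70 log units; beyond the scatter). Within the data shown here, the earlier compounds differ from one another in more than one place, so only this pair shows that the number responds to a group on this nitrogen. The step is a floor and not a full measured size: the limit of > 30000 nM in this assay, at which 2 of the 4 values shown sit.

As far as these compounds go, it remains open whether the lower number depends on the double bond of the allyloxy group, which a saturated propoxy group on the same nitrogen would test. From the compounds shown here alone, it also remains open whether a larger benzyloxy group or an amine-bearing chain there would lower the number further or raise it again.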